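The source may hold more compounds than are shown below. What is called first, only, known or untested is meant among the compounds shown, and "the series" means these compounds.

The series rests on one shared core, seen in compound 1 `C#CCNC1CCc2c(SCCc3cccc(Br)c3)cccc21`. In an ADME assay on isolated protein for inhibition of Amine oxidase [flavin-containing] B (Homo sapiens) (a lower number here means a stronger inhibitor, a higher number a weaker inhibitor), compound 1 gives 620 nM, which places it second highest of the three numbers recorded so far. The nearest neighbour of compound 1 is compound 3 `C#CCNC1CCc2c(SCc3ccc(Br)cc3)cccc21`; in this assay compound 3 gives 488 nM, a gap that stays within the scatter of repeated measurements. Compound 2 `C#CCNC1CCc2c(SCc3cccc(C(F)(F)F)c3)cccc21` lies furthest away, giving 7710 nM in this assay, a gap well beyond that scatter. Compound 4 `C#CCNC1CCc2c(SCCc3ccc(Cl)cc3)cccc21` has not yet been measured in this assay. It differs from compound 1 in a single place: 4-chlorophenyl in place of 3-bromophenyl on a saturated chain carbon, two bonds along the chain from a sulfur. Among the measured compounds shown here, no pair of measured compounds reproduces this exact change, so the expectation rests on the three values alone. Because compound 3 gives 488 nM, a number within the scatter of compound 1, a large shift from this kind of ring change is not expected, although compound 2 shows that some ring changes do move the number far. The step of a 1.4-fold lower number from compound 1 to compound 4 (0.14 log units; within the scatter) is estimated to be small, toward a slightly lower number. Compound 4 is expected to give 450 nM in this assay, within a range from 150 nM to 1500 nM.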

Compound 4, half-maximal inhibitory concentration: 920 nM
Estimate against measurement, compound 4: 2.0-fold (0.31 log units) below; the range from low to high includes it.
By their numbers in this assay, from the lowest: compounds 3, 1 and 4 (each within the scatter of the next); then compound 2.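

In this assay, among the compounds shown here, this is the first step that reads a single change at this position (a 1.5-fold higher number from compound 1 to compound 4 (0.17 log units; within the scatter)): 4-chlorophenyl takes the place of 3-bromophenyl on a saturated chain carbon, two bonds along the chain from a sulfur, and the number stays within the scatter of repeated measurements. The change alters both the halogen and its place on the ring, and this single step cannot separate the two. Nothing measured here accounts for the result.

The compounds shown leave open whether either of those two alterations, taken alone, would move the number. They also leave open how a nitrile or a methoxy group on the same ring, or a longer chain between the ring and the sulfur, would read in this assay.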